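Fluoro to hydrogen on compound 2

The source may hold more compounds than are shown below. What is called first, only, known or untested is meant among the compounds shown, and "the series" means these compounds.

Measured so far in a functional assay on U-87MG ATCC cells (Homo sapiens) for cytotoxicity, read by MTT assay, with a stated time of 48 h; a higher number here means a weaker inhibitor, a lower number a stronger inhibitor:
- compound 1 `C/C(=N\NC(=S)Nc1cccc(F)c1)c1ccccn1`: 18 nM
- compound 2 `CC(=NNC(=S)Nc1cccc(F)c1)c1ccccn1`: 18 nM
- compound 3 `C/C(=N/NC(=S)Nc1ccccc1F)c1ccccn1`: 5 nM

Compound 2 stands level with compound 1 at the top of these three numbers, and compound 3 lies beyond the scatter below them. The next compound to be tested is compound 4 `CC(=NNC(=S)Nc1ccccc1)c1ccccn1`, with the change (hydrogen in place of fluoro on an aromatic carbon), hydrogen in place of fluoro on an aromatic carbon.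

Going by the values given here, the only measured single-place step is no change at the digits printed from compound 1 to compound 2 (within the scatter), and it concerns just (the fact that one of compounds 1 and 2 is drawn with a defined configuration and the other without, at the place where they differ). It therefore gives no size for losing the fluoro. Compound 3, at 5 nM, differs from compound 2 in more than one place, but it shows that numbers in this small set can move beyond the scatter, so the range is kept wide. Among the compounds with values here, with no measured step pointing either way, no shift beyond the scatter is expected in this assay, and the estimated change is a 1.1-fold higher number from compound 2 to compound 4 (0.05 log units; within the scatter). The expected value for compound 4 is 20 nM, with an estimated range of 6 nM to 70 nM.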

Compound 4, half-maximal inhibitory concentration: 1.4 nM
For compound 4 the middle estimate is 14-fold (1.15 log units) above the measured one; the whole stated range lies above it.
By their numbers in this assay, from the lowest: compound 4; then compound 3; then compounds 1 and 2 (each within the scatter of the next).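

In this assay, replacing the fluoro on this aromatic carbon, meta to a large group, with hydrogen gives a 13-fold lower number from compound 2 to compound 4 (1.11 log units; beyond the scatter), so the loss of one heavy atom at this position is enough to move the number well beyond the scatter, and toward stronger inhibition. Going by these compounds alone, the only earlier single-place step, no change at the digits printed from compound 1 to compound 2 (within the scatter), concerned a drawn configuration alone, so this is the first measured size for a change of substituent on this ring. Nothing available explains the size of the step.

Within the data shown here, the single pair leaves open whether the shift is specific to losing the fluoro or whether other groups at this place would also be tolerated, as a chloro, a methyl, a methoxy or an amine on the same carbon would show. It also leaves open whether removing a fluoro from another ring position would produce a step of similar size.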